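The source may report more compounds than this note shows. Statements on the series, on what has been measured and on what is new or still open speak of the compounds shown alone.

Compound 1 `CC(C)c1ncncc1-c1nc2cc(F)c(F)cc2n1C1CC1` and compound 2 `CNc1ncncc1-c1nc2cc(F)c(F)cc2n1C1CC1` share one core and differ in a single group on the six-membered ring with two nitrogens. In an ADME assay on cells for inhibition of cytochrome P450 11B1, mitochondrial (Homo sapiens), read by HPLC, with a stated time of 60 min (a lower number here means a stronger inhibitor, a higher number a weaker inhibitor), compound 1 gives 1910 nM, and in the same assay compound 2 gives 390 nM. Within the data shown here, the step of a 4.9-fold lower number from compound 1 to compound 2 (0.69 log units; beyond the scatter) is the only measured step, and it places compound 2 at the lower of the two numbers so far.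

Compound 3 `Fc1cc2nc(-c3cncnc3C(F)(F)F)n(C3CC3)c2cc1F` carries the change (trifluoromethyl in place of methylamino on an aromatic carbon). Among the measured compounds shown here, no measured step covers this exact exchange; the one that bears on it is the exchange of isopropyl for methylamino, which moved the number by a 4.9-fold lower number from compound 1 to compound 2 (0.69 log units; beyond the scatter). Since compound 3 gives up the methylamino that accompanied that lower number, the estimate for compound 3 in this assay is 1500 nM, within 500 nM to 5000 nM, which would mean a step of a 3.8-fold higher number from compound 2 to compound 3 (0.59 log units; beyond the scatter) toward a weaker inhibitor.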

Compound 3, half-maximal inhibitory concentration: 4770 nM
Compound 3: middle estimate off by 3.2-fold (0.50 log units), on the low side; low and high end bracket the measured number.
By their numbers in this assay, from the lowest: compound 2; then compound 1; then compound 3.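

In this assay, trifluoromethyl in place of methylamino gives a 12-fold higher number from compound 2 to compound 3 (1.09 log units; beyond the scatter), a large step, so this position responds strongly to the group it carries. Trifluoromethyl in place of isopropyl gives a 2.5-fold higher number from compound 1 to compound 3 (0.40 log units; beyond the scatter), which shows that compound 1 did not mark the weak end of the range here and places the three groups in the order methylamino, isopropyl, trifluoromethyl, from the lowest number to the highest. Nothing measured here explains this order, and the exchange between compound 2 and compound 3 changes the hydrogen-bond donor and acceptor counts and the heavy-atom count together, so these cannot be separated.

The compounds shown leave open where a plain amine, a dimethylamino group or a methoxy group would fall in this order. They also leave open whether the order holds on a different core.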